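A Single Stereocentre Change from Compound 2 to Compound 3

The source may hold more compounds than are shown below. What is called first, only, known or untested is meant among the compounds shown, and "the series" means these compounds.

Compound 1: `CC(=O)N[C@H]1[C@@H](OC2=CC(=O)c3ccccc3C2=O)O[C@H](COC(C)=O)[C@@H](OC(C)=O)[C@@H]1OC(C)=O` — 19800 nM
Compound 2: `O=C1C=C(OCc2cn([C@@H]3O[C@H](CO)[C@@H](O)[C@H](O)[C@H]3O)nn2)C(=O)c2ccccc21` — > 50000 nM

Of the compounds shown here, two have so far been measured in a functional assay on MDA-MB-231 cells (Homo sapiens) for cytotoxicity, read by sulforhodamine B assay, with a stated time of 72 h; on this read-out lower numbers stand for stronger inhibition and higher numbers for weaker inhibition. Compound 1, a peracetylated sugar carrying the shared core, gives 19800 nM in this assay. Compound 2 stands differently: in this assay compound 2 gives > 50000 nM, and this is a limit of the assay rather than a number, so nothing more than that limit is known for it. Compound 2 thus sits at the limit of > 50000 nM in this assay, at which 1 of the 2 values shown sits.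

The next compound, compound 3, is `O=C1C=C(OCc2cn([C@@H]3O[C@H](CO)[C@H](O)[C@H](O)[C@H]3O)nn2)C(=O)c2ccccc21`. Compared with compound 2, the change is as follows: the two compounds have the same atoms and bonds and differ only in configuration as drawn: 1 of 5 stereo elements differ; a stereocentre at a saturated ring carbon is drawn S in compound 2 and R in compound 3. Since compound 2 has only a limit, no direction of change can be read from the numbers, and a single change of configuration at one saturated ring carbon gives no ground for expecting a step beyond the usual scatter in this assay. The step from compound 2 to compound 3 is therefore expected to be a step that the limit leaves unreadable from compound 2 to compound 3. Compound 3 is estimated to give about 80000 nM in this assay, within a range from 30000 nM to 200000 nM, most likely again reported only as a limit.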

Compound 3, half-maximal inhibitory concentration: > 50000 nM
Compound 3 was reported as a limit (the forecaster's own chance of this, stated with the estimate: 80%); the middle value lies beyond the limit too.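

In this assay compound 3 gives > 50000 nM as a limit of the assay and not as a number. Among the compounds shown here, no step from compound 2 to compound 3 can be read, because both compounds stand at the same limit: the limit of > 50000 nM in this assay, at which 2 of the 3 values shown sit. The compounds shown leave open whether the configuration at that saturated ring carbon makes any difference to cytotoxicity.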